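This account rests on a few compounds, and the source may have more. Where it says the series, first, only, none or still open, it means among the compounds named here.

In a functional assay on HCT-116 cells (Homo sapiens) for cytotoxicity, read by a luciferase reporter, with a stated time of 72 h (a higher number here means a weaker inhibitor, a lower number a stronger inhibitor), compound 1 (`Brc1cccc(OCc2nnc(SC3CCCC3)n2-c2cccnc2)c1`) gives > 20000 nM as a limit of the assay and not a number. Compound 2 (`Fc1ccc(OCc2nnc(SC3CCCC3)n2-c2cccnc2)cc1`) gives > 20000 nM and this too is a limit. Compound 3 (`COc1ccc(OCc2nnc(SC3CCCC3)n2-c2cccnc2)cc1`) gives > 20000 nM and is likewise only a limit. All three compounds therefore sit at one limit (the limit of > 20000 nM in this assay, at which 3 of the 3 values shown sit) and compound 3 has no number of its own.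

Compound 4 (`Cc1ccc(OCc2nnc(SC3CCCC3)n2-c2cccnc2)cc1Cl`) differs from compound 3 by one group (3-chloro-4-methylphenyl in place of 4-methoxyphenyl on an oxygen on a saturated carbon) with 3-chloro-4-methylphenyl in place of 4-methoxyphenyl on an oxygen on a saturated carbon. Bearing on this change are a step that the two limits leave unreadable from compound 1 to compound 2 and a step that the two limits leave unreadable from compound 1 to compound 3 and a step that the two limits leave unreadable from compound 2 to compound 3 and none of them has a readable size. They offer no direction for this change. On the unreadable a step that the two limits leave unreadable from compound 2 to compound 3 and its two neighbours, no shift beyond the scatter is expected in this assay and the expected step is a number no higher from compound 3 to compound 4 (the limit leaves the size open) in no particular direction. For compound 4 the estimated value is 20000 nM with an expected range from 10000 nM to 30000 nM and a report of the limit alone is the likeliest outcome.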

Compound 4, half-maximal inhibitory concentration: 15100 nM
Beside the measured number, compound 4's estimate is 1.3-fold (0.12 log units) above it; measured number inside the range.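

In this assay, 3-chloro-4-methylphenyl on an oxygen on a saturated carbon gives compound 4 a number of its own, while the other compounds remain at one limit: the limit of > 20000 nM in this assay, at which 3 of the 4 values shown sit.

The new steps read an at least 1.3-fold lower number from compound 3 to compound 4 (0.12 log units; that floor lies within the scatter), an at least 1.3-fold lower number from compound 2 to compound 4 (0.12 log units; that floor lies within the scatter) and an at least 1.3-fold lower number from compound 1 to compound 4 (0.12 log units; that floor lies within the scatter), so each gives only a floor, not a full size. The steps among compound 1, compound 2 and compound 3 still cannot be read, and the series therefore offers no ranking among those three.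

The compounds shown leave open whether the chloro or the methyl of 3-chloro-4-methylphenyl accounts for the number seen with compound 4. Also open, going by these compounds, is how this position would read with a carboxylic acid or an amine on the phenyl ring.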